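Alkoxy group at the shared core and receptor binding

The source may report more compounds than this note shows. Statements on the series, on what has been measured and on what is new or still open speak of the compounds shown alone.

Measured compounds:
- compound 1 `CCC(C)COc1cccc2ccc(N)nc12`: 36 nM
- compound 2 `Nc1ccc2cccc(OCC3CCCC3)c2n1`: 53 nM
- compound 3 `CCCCCOc1cccc2ccc(N)nc12`: 580 nM

Compound 2 stands second highest of the three numbers in an assay on cells with melanin-concentrating hormone receptor 1 (Homo sapiens) as the target, read by radioligand binding; on this read-out lower numbers stand for stronger inhibition and higher numbers for weaker inhibition; its nearest neighbour is compound 1, with a 1.5-fold higher number from compound 1 to compound 2 (0.17 log units; within the scatter), and its furthest compound 3, with an 11-fold higher number from compound 2 to compound 3 (1.04 log units; beyond the scatter).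

Compound 4 `CCCCOc1cccc2ccc(N)nc12` differs from compound 2 by propyl in place of cyclopentyl on a saturated chain carbon bound to an oxygen on an aromatic ring. For the measured compounds named here, two measured steps bear on this: an 11-fold higher number from compound 2 to compound 3 (1.04 log units; beyond the scatter) and a 16-fold higher number from compound 1 to compound 3 (1.21 log units; beyond the scatter), where the group that enters has no ring, as propyl has none. A weakening step of similar size is therefore expected, with a 9.4-fold higher number from compound 2 to compound 4 (0.97 log units; beyond the scatter).

For compound 4 the expected value is 500 nM, with a range from 150 nM to 1600 nM.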

Compound 4, half-maximal inhibitory concentration: 789 nM
Compound 4: the middle estimate sits 1.6-fold (0.20 log units) below what was measured; low and high end bracket the measured number.
By their numbers in this assay, from the lowest: compounds 1 and 2 (each within the scatter of the next); then compounds 3 and 4 (each within the scatter of the next).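

In this assay, shortening the unbranched chain shifts the number only within the scatter (a 1.4-fold higher number from compound 3 to compound 4 (0.13 log units; within the scatter)), so chain length, over these two chains, does not separate compounds. For the compounds shown here, removing the single branching methyl (a 22-fold higher number from compound 1 to compound 4 (1.34 log units; beyond the scatter)) or replacing cyclopentyl with propyl (a 15-fold higher number from compound 2 to compound 4 (1.17 log units; beyond the scatter)) moves the number far more, and across these four compounds the lower numbers go with a branch or ring on the chain, with no compound against this. Nothing available accounts for this difference.

Still open, on these data alone, is whether a smaller ring, such as cyclopropyl, keeps the lower numbers. The same holds for a branched longer chain or an amine on the chain.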